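Chain extension on two amine-bearing cores

The source may hold more compounds than are shown below. What is called first, only, known or untested is meant among the compounds shown, and "the series" means these compounds.

Compound 1 `CCC(=O)NCCC(=O)c1cc(OC)ccc1N` and compound 2 `CCCC(=O)NCCC(=O)c1cc(OC)ccc1N` share one core; in an assay for inhibition of Nitric oxide synthase, inducible (Homo sapiens), read by scintillation counting, with a stated time of 30 min, tested at 1 mM (on this read-out lower numbers stand for less inhibition and higher numbers for more inhibition at the one concentration tested (going by the name of the read-out)), compound 1 gives 0.24% and compound 2 gives 7.35%. The change between them is methyl in place of hydrogen on a saturated chain carbon, two bonds along the chain from a carbonyl carbon, and the step is a number 7.1 percentage points higher from compound 1 to compound 2 (within the scatter). Compound 3 `CCNC(=S)NCCC(O)c1ccccc1N` stands on a different core, and the difference between the two cores is not broken down here. In this assay compound 3 gives 19.4%, the highest of the three numbers, beyond the scatter from both others. Compound 4 `CCCNC(=S)NCCC(O)c1ccccc1N` differs from compound 3 by methyl in place of hydrogen on a saturated chain carbon, two bonds along the chain from an amide-type nitrogen. This is the same kind of change as before, though the place differs: there the saturated chain carbon lies two bonds along the chain from a carbonyl carbon, here two bonds along the chain from an amide-type nitrogen. The step for compound 4 is expected to be a number 4.6 percentage points higher from compound 3 to compound 4 (within the scatter), since the earlier change gave a number 7.1 percentage points higher from compound 1 to compound 2 (within the scatter). Compound 4 is estimated at 24%, with an expected range from 10% to 40%.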

Compound 4, a percentage reported as inhibition, at one concentration (the size of the read-out at that concentration, not a potency): 31.1%
Compound 4: middle estimate off by 7.1 percentage points, on the low side, and the stated range covers the measured number.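

Going by these compounds alone, the step on the core of compound 3 is a number 11.7 percentage points higher from compound 3 to compound 4 (beyond the scatter), and set beside the step on the other core it differs by no more than the scatter: the same change on two cores in this assay, a number 7.1 percentage points higher (within the scatter) from compound 1 to compound 2 and a number 11.7 percentage points higher (beyond the scatter) from compound 3 to compound 4, 4.6 percentage points apart, within the scatter of two such steps The change therefore carries between these two cores with no measurable difference in size, although only the step on the core of compound 3 lies beyond the scatter. Two steps, at different places on the chain, do not show that it would carry to a further core, and single-concentration percentages say nothing of potency.

Still open, on these data alone, is whether a longer chain, such as butyl, would add further on the core of compound 3. Also open, as far as these compounds go, is how an amine or a carboxylic acid would read in place of the methyl.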